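Hydroxy for chloro on the urea aryl group

The source may hold more compounds than are shown below. What is called first, only, known or untested is meant among the compounds shown, and "the series" means these compounds.

In a functional assay on HeLa cells (Homo sapiens) for inhibition, read by MTT assay, with a stated time of 72 h (on this read-out lower numbers stand for stronger inhibition and higher numbers for weaker inhibition), compound 1 (`COc1cc(NC(C)CCCNC(=O)Nc2cccc(Cl)c2)c2ncccc2c1`) gives 17000 nM, compound 2 (`COc1cc(NC(C)CCCNC(=O)Nc2ccc(F)cc2)c2ncccc2c1`) gives 20000 nM and compound 3 (`COc1cc(NC(C)CCCNC(=O)Nc2ccc(Cl)cc2)c2ncccc2c1`) gives 18000 nM. The three values cannot be separated, so compound 3 holds no distinct place among them: the data show a 1.1-fold higher number from compound 1 to compound 3 (0.02 log units; within the scatter) and a 1.1-fold lower number from compound 2 to compound 3 (0.05 log units; within the scatter).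

The next structure is compound 4 (`COc1cc(NC(C)CCCNC(=O)Nc2ccc(O)cc2)c2ncccc2c1`), with hydroxy in place of chloro on an aromatic carbon, para to a large group: hydroxy in place of chloro on an aromatic carbon.

Within the data shown here, three measured steps bear on this change. Exchanging the halogen at that place gave a 1.1-fold lower number from compound 2 to compound 3 (0.05 log units; within the scatter), moving the chloro gave a 1.1-fold higher number from compound 1 to compound 3 (0.02 log units; within the scatter), and the remaining pair gave a 1.2-fold higher number from compound 1 to compound 2 (0.07 log units; within the scatter). All of them stay within the scatter, but none introduces a hydroxy group, so the range is kept wide. No step beyond the scatter is expected in this assay.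

The estimated step is a 1.2-fold higher number from compound 3 to compound 4 (0.07 log units; within the scatter).

Compound 4 is expected at 21000 nM, with an estimated range of 10000 nM to 45000 nM.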

Compound 4, half-maximal inhibitory concentration: 70000 nM
The estimate for compound 4 lay 3.3-fold (0.52 log units) below the measured number; measured number outside the range, above it.
By their numbers in this assay, from the lowest: compounds 1, 3 and 2 (each within the scatter of the next); then compound 4.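

In this assay this place on the urea aryl group proves sensitive to the exchange: hydroxy for chloro gives a 3.9-fold higher number from compound 3 to compound 4 (0.59 log units; beyond the scatter) and hydroxy for fluoro gives a 3.5-fold higher number from compound 2 to compound 4 (0.54 log units; beyond the scatter) while the exchange between the two halogens stayed within the scatter. The comparison with the 3-chlorophenyl compound reads the same way, with a 4.1-fold higher number from compound 1 to compound 4 (0.61 log units; beyond the scatter) so the three halogen-bearing compounds stay together and compound 4 is the weakest of the four, though the step is modest. No measurement at hand accounts for this loss.
Open, on these data alone, is whether a methoxy group, an amine or a carboxylic acid at this place would sit with compound 4 or with the halogen compounds. Also open, as far as these compounds go, is whether hydroxy in place of the chloro of compound 1 would give a similar step.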